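This account rests on a few compounds, and the source may have more. Where it says the series, first, only, none or still open, it means among the compounds named here.

Compound 1 `CC(C)[C@H](NC(=O)COc1cccc2ccccc12)C(=O)N[C@@H](CC(=O)O)C(=O)COc1ccc2ccccc2c1` was tested in a functional assay on Jurkat cells (Homo sapiens); on this read-out lower numbers stand for stronger inhibition and higher numbers for weaker inhibition. In this assay compound 1 gives only a limit, > 100000 nM, and not a number. Compound 2 `CC(C)[C@H](NC(=O)COc1cccc2ccccc12)C(=O)N[C@@H](CC(=O)O)C(=O)COc1cc(C(F)(F)F)cc(C(F)(F)F)c1` likewise gives only a limit in this assay, > 100000 nM. Both measured values sit at the limit of > 100000 nM in this assay, at which 2 of the 2 values shown sit. Compound 3 `CC(C)[C@H](NC(=O)COc1cccc2ccccc12)C(=O)N[C@@H](CC(=O)O)C(=O)COc1ccccc1[N+](=O)[O-]` has not yet been measured; it differs from compound 1 in one place: 2-nitrophenyl in place of naphthalen-2-yl on an oxygen on a saturated carbon. Going by the values given here, with no measured step between two numbered values to go by, the step from compound 1 to compound 3 is expected to be a number no higher from compound 1 to compound 3 (the limit leaves the size open), which is none beyond the scatter. For compound 3 the expected value in this assay is 100000 nM, with a range from 30000 nM to 300000 nM, and most likely again only a limit.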

Compound 3, half-maximal inhibitory concentration: > 100000 nM
Compound 3: only a limit was reported; the forecaster's own chance of this, stated with the estimate: 85%; the middle value lies on the limit itself.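

Going by these compounds alone, compound 1 and compound 3 both give only limits in this assay, so no step between them can be read. The compounds shown leave open whether any group in this place would give a measurable inhibition value.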